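The source may report more compounds than this note shows. Statements on the series, on what has been measured and on what is new or still open speak of the compounds shown alone.

In a functional assay on CLL cells (Homo sapiens) for cytotoxicity, read by MTT assay, with a stated time of 48 h (on this read-out higher numbers stand for an effect only at larger amounts of compound and lower numbers for an effect already at smaller amounts), compound 3 (`C=C(CC)C(=O)c1ccc(OCC(=O)NCCCN2CCCC2=O)c(Cl)c1Cl`) gives 13800 nM, level with compound 2 (`C=C(CC)C(=O)c1ccc(OCC(=O)Nc2ccc(C(=O)O)cn2)c(Cl)c1Cl`) at 14900 nM. Compound 1 (`C=C(CC)C(=O)c1ccc(OCC(=O)NCC(=O)O)c(Cl)c1Cl`) reaches only a limit, > 25000 nM. Its steps, an at least 1.6-fold lower number from compound 1 to compound 2 (0.22 log units; that floor lies within the scatter) and an at least 1.8-fold lower number from compound 1 to compound 3 (0.25 log units; that floor lies within the scatter), are floors that stay within the scatter. Compound 4 (`C=C(CC)C(=O)c1ccc(OCC(=O)Nc2nc3ccccc3s2)c(Cl)c1Cl`) carries 1,3-benzothiazol-2-yl in place of 3-(2-oxopyrrolidin-1-yl)propyl on an amide-type nitrogen. Among the measured compounds shown here, the closest precedent is the swap on that same nitrogen, a 1.1-fold lower number from compound 2 to compound 3 (0.03 log units; within the scatter), which leaves the number essentially unmoved. The expected step is therefore small, a 1.5-fold lower number from compound 3 to compound 4 (0.19 log units; within the scatter), and no larger than the scatter. For compound 4 the estimated value in this assay is 9000 nM, with an expected range of 3000 nM to 22000 nM.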

Compound 4, half-maximal effective concentration: 1500 nM
The estimate for compound 4 lay 6.0-fold (0.78 log units) above the measured number; measured number outside the range, below it.
By their numbers in this assay, from the lowest: compound 4; then compounds 3 and 2 (each within the scatter of the next). At a limit, above all of these: compound 1.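

In this assay, among the compounds shown here, 1,3-benzothiazol-2-yl on the amide-type nitrogen is the first group to move the number beyond the scatter: a 9.2-fold lower number from compound 3 to compound 4 (0.96 log units; beyond the scatter) and a 9.9-fold lower number from compound 2 to compound 4 (1.00 log units; beyond the scatter), although 5-carboxypyridin-2-yl, also an aromatic ring on that nitrogen, stays level with the 3-(2-oxopyrrolidin-1-yl)propyl group. The third step, an at least 16-fold lower number from compound 1 to compound 4 (1.22 log units; beyond the scatter), is only a floor. Compound 1 stands at a limit of the assay: the limit of > 25000 nM in this assay, at which 1 of the 4 values shown sits.

The compounds shown leave open whether a plain phenyl or a 1,3-benzoxazol-2-yl on that nitrogen would keep this gain. They also leave open whether the sulfur or the fused ring carries it.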